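Selenium-Benzyl Group Replacing Methylsulfanyl: Expected Cytotoxicity

The compounds below may be only part of what the source reports. "The series", "measured", "known", "first", "only" and "open" are said of these compounds alone.

Measured compounds:
Compound 1 `CS/C(=N\C(=O)c1csc([N+](=O)[O-])c1)NC(=O)c1csc([N+](=O)[O-])c1`; in a functional assay on MCF7 cells (Homo sapiens) for cytotoxicity, read by MTT assay, with a stated time of 72 h (a higher number here means that more compound is tolerated, a lower number that less compound is tolerated), compound 1 gives > 100000 nM, a limit of the assay rather than a number.
Compound 2 `CS/C(=N\C(=O)c1ccco1)NC(=O)c1ccco1`; compound 2 gives > 100000 nM, again a limit.
Compound 3 `O=C(/N=C(/NC(=O)c1ccco1)[Se]Cc1ccccc1)c1ccco1`; compound 3 gives > 100000 nM, also a limit.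

Going from compound 2 to compound 3 makes the change (a group of 8 heavy atoms (7 carbon, 1 selenium; one six-membered aromatic ring of carbon only) in place of a group of 2 heavy atoms (1 carbon, 1 sulfur; no ring), on a carbon with a double bond to nitrogen), and the step that the two limits leave unreadable from compound 2 to compound 3 cannot be read, as both ends are limits. Compound 4 `O=C(/N=C(/NC(=O)c1csc([N+](=O)[O-])c1)[Se]Cc1ccccc1)c1csc([N+](=O)[O-])c1` carries the same change on the core of compound 1, namely (a group of 8 heavy atoms (7 carbon, 1 selenium; one six-membered aromatic ring of carbon only) in place of a group of 2 heavy atoms (1 carbon, 1 sulfur; no ring), on a carbon with a double bond to nitrogen); the difference between the two cores is not broken down here. Within the data shown here, since every value sits at the limit (the limit of > 100000 nM in this assay, at which 3 of the 3 values shown sit), no step in this assay is readable at all. Compound 4 is therefore expected to show a step that the limit leaves unreadable from compound 1 to compound 4. The estimate for compound 4 is 150000 nM, between 50000 nM and 500000 nM, and most likely it is again reported only as a limit.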

Compound 4, concentration lethal to 50% of the cells: 83800 nM
Beside the measured number, compound 4's estimate is 1.8-fold (0.25 log units) above it, within the range that was stated.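

Swapping methylsulfanyl for the selenium-benzyl group gives, in this assay, an at least 1.1-fold lower number from compound 1 to compound 4 (0.07 log units; that floor lies within the scatter), so this step cannot be told apart from ordinary repeat-to-repeat variation. The same swap on the other core cannot be read, as compound 2 and compound 3 are both reported only as limits, so nothing shows whether the change carries from one core to the other. Compound 4 alone gives an actual number, and the true size of its step stays unknown: the limit of > 100000 nM in this assay, at which 3 of the 4 values shown sit.

The compounds shown leave open whether the selenium or the benzyl ring matters more, for instance how a benzyl group on sulfur would read. Also open, on these data alone, is how an amine or a longer chain would read on a carbon with a double bond to nitrogen.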